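Swapping the benzyl aryl group in a sulfonyl guanidine series

The source may report more compounds than this note shows. Statements on the series, on what has been measured and on what is new or still open speak of the compounds shown alone.

The compounds measured so far, and their numbers:
- Compound 1, `Cc1ccc(CSc2cc(Cl)c(C)cc2S(=O)(=O)/N=C(\N)n2nc(C)cc2-c2ccccc2)cc1`: in an ADME assay on microsomes from liver (Homo sapiens) for metabolic stability, read by LC-MS, using NADPH, tested at 5 uM (a higher number here means that the compound lasts longer, a lower number that the compound disappears faster), compound 1 gives 0.176 h.
- Compound 2, `Cc1cc(S(=O)(=O)/N=C(\N)n2nccc2-c2ccccc2)c(SCc2cccc(Cl)c2)cc1Cl`: in this assay compound 2 gives 0.309 h.
- Compound 3, `Cc1cc(-c2ccccc2)n(/C(N)=N/S(=O)(=O)c2cc(C)c(Cl)cc2SCc2cccc(Cl)c2)n1`: in this assay compound 3 gives 0.205 h.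

Compound 2 has the highest of these three numbers, yet its gaps to compound 3 and to compound 1 both stay within the scatter, so nothing separates the three in a way that can be trusted.

Compound 4, `Cc1cc(S(=O)(=O)/N=C(\N)n2nccc2-c2ccccc2)c(SCc2ccccc2C)cc1Cl`, is not yet measured. It differs from compound 2 in one place: 2-methylphenyl in place of 3-chlorophenyl on a saturated chain carbon bound to a sulfur. Going by the values given here, this is a swap of the aryl group carried on that chain carbon, and only one measured step touches that position: a 1.2-fold higher number from compound 1 to compound 3 (0.07 log units; within the scatter). The other step changes a different place, a methyl on an aromatic carbon, and is also small: a 1.5-fold lower number from compound 2 to compound 3 (0.18 log units; within the scatter). Both are within the scatter, so no step beyond the scatter is expected in this assay for compound 4 either.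

Compound 4 is therefore estimated at 0.25 h, in a range from 0.12 h to 0.5 h. The step from compound 2 that this estimate means, a 1.2-fold lower number from compound 2 to compound 4 (0.09 log units; within the scatter), is expected to stay within the scatter.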

Compound 4, half-life: 0.0802 h
The estimate for compound 4 lay 3.1-fold (0.49 log units) above the measured number; measured number below the stated range.
By their numbers in this assay, from the lowest: compound 4; then compounds 1, 3 and 2 (each within the scatter of the next).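

In this assay, going by these compounds alone, the aryl group on a saturated chain carbon bound to a sulfur proves able to move the half-life: the change to 2-methylphenyl from 3-chlorophenyl gives a 3.9-fold lower number from compound 2 to compound 4 (0.59 log units; beyond the scatter), while the only earlier change at this place, made on another core, gave a 1.2-fold higher number from compound 1 to compound 3 (0.07 log units; within the scatter). The two groups that trade places are alike in what can be counted, each with the same number of heavy atoms, one six-membered aromatic ring of carbon only and no hydrogen-bond donors or acceptors, so these counts do not separate them. No measurement at hand explains why the half-life of compound 4 is shorter.

This swap changes both the substituent on the ring, chlorine for methyl, and its place on that ring, and the compounds shown do not pull these two apart, so it stays open which of them matters. Going by these compounds, it also stays open how the half-life would respond to a quite different group at this place, such as a pyridine ring, an amine or a longer chain.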